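Swapping methyl for fluoro on compound 3

The compounds below may be only part of what the source reports. "The series", "measured", "known", "first", "only" and "open" are said of these compounds alone.

compound 1 `Cc1ccccc1NNC(=O)c1cccc(NS(=O)(=O)c2cnc(O)nc2O)c1` gives 14200 nM
compound 2 `Cc1cccc(NNC(=O)c2cccc(NS(=O)(=O)c3cnc(O)nc3O)c2)c1` gives > 20000 nM
compound 3 `Cc1ccccc1C(=O)NNC(=O)c1cccc(NS(=O)(=O)c2cnc(O)nc2O)c1` gives 8010 nM

All three values come from a functional assay on A549 cells (Homo sapiens) for antiproliferative activity, read by MTT assay, with a stated time of 24 h (on this read-out higher numbers stand for weaker inhibition and lower numbers for stronger inhibition), and the value for compound 2 is a limit of the assay and not a number. Compound 3 cannot be told apart from compound 1 on these numbers, since there is a 1.8-fold lower number from compound 1 to compound 3 (0.25 log units; within the scatter) between them. It does stand clear of the limit, with an at least 2.4-fold lower number from compound 2 to compound 3 (0.39 log units; beyond the scatter) to show for it.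

The next compound is compound 4 `O=C(NNC(=O)c1ccccc1F)c1cccc(NS(=O)(=O)c2cnc(O)nc2O)c1` which has fluoro in place of methyl on an aromatic carbon.

Within the data shown here, no measured step makes this swap. The closest guides are an at least 1.4-fold higher number from compound 1 to compound 2 (0.14 log units; that floor lies within the scatter) for moving the methyl and a 1.8-fold lower number from compound 1 to compound 3 (0.25 log units; within the scatter) for adding a carbonyl, and neither goes beyond the scatter on its number. Only an at least 2.4-fold lower number from compound 2 to compound 3 (0.39 log units; beyond the scatter) does so, and that is a larger structural change. A small swap should therefore leave this assay little changed.

The expected change is a 1.1-fold higher number from compound 3 to compound 4 (0.05 log units; within the scatter) and no shift beyond the scatter is expected. For compound 4 the estimate is 9000 nM with an expected range from 3500 nM to 20000 nM as its ends.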

Compound 4, half-maximal inhibitory concentration: 10800 nM
Beside the measured number, compound 4's estimate is 1.2-fold (0.08 log units) below it, within the range that was stated.
By their numbers in this assay, from the lowest: compounds 3, 4 and 1 (each within the scatter of the next). At a limit, above all of these: compound 2.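

On this aromatic carbon, ortho to a large group, methyl and fluoro cannot be told apart in this assay: there is a 1.3-fold higher number from compound 3 to compound 4 (0.13 log units; within the scatter), so this position takes either group with no shift that stands clear of the scatter. The wider swap on the amine nitrogen reads the same way, with a 1.3-fold lower number from compound 1 to compound 4 (0.12 log units; within the scatter), and compound 4 cannot be separated from compound 1 either. Compound 2 gives a limit and not a number, and an at least 1.8-fold lower number from compound 2 to compound 4 (0.26 log units; that floor lies within the scatter), so compound 4 does not stand clear of that limit as compound 3 did: the limit of > 20000 nM in this assay, at which 1 of the 4 values shown sits.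

Methyl and fluoro are both single small groups, so they test only a narrow part of what this position might accept. From the compounds shown here alone, whether a methoxy group, an amine or a longer chain in the same place would move the number beyond the scatter stays open.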